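Ester-Bearing Amine Replaces Methylpiperazine on Two Cores

The compounds below may be only part of what the source reports. "The series", "measured", "known", "first", "only" and "open" are said of these compounds alone.

Compound 1 `CN1CCN(CC#Cc2cc3c(Nc4ccc(OCc5cccc(F)c5)c(Cl)c4)ncnc3s2)CC1` carries a 4-methylpiperazin-1-yl group on a saturated chain carbon bound to a triple-bonded carbon. In an ADME assay on HepG2 cells (Homo sapiens) for cytotoxicity (on this read-out lower numbers stand for higher toxicity in this test and higher numbers for lower toxicity in this test), compound 1 gives 15 uM. Compound 2 `CCOC(=O)CN(C)CC#Cc1cc2c(Nc3ccc(OCc4cccc(F)c4)c(Cl)c3)ncnc2s1` differs from compound 1 by ((ethoxycarbonyl)methyl)(methyl)amino in place of 4-methylpiperazin-1-yl on a saturated chain carbon bound to a triple-bonded carbon. For compound 2 the read-out in this assay is a limit of the assay, > 28 uM, and not a number. The step of an at least 1.8-fold higher number from compound 1 to compound 2 (0.27 log units; that floor lies within the scatter) therefore has only a floor, which comes from the limit of > 28 uM in this assay, at which 1 of the 3 values shown sits.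

Compound 3 `CN1CCN(CC#Cc2ccc3ncnc(Nc4ccc(OCc5cccc(F)c5)c(Cl)c4)c3c2)CC1` carries the same 4-methylpiperazin-1-yl group on a different core; the difference between the two cores is not broken down here. In this assay compound 3 gives 8.2 uM, a value that sits within the scatter of the value of compound 1. Compound 4 `CCOC(=O)CN(C)CC#Cc1ccc2ncnc(Nc3ccc(OCc4cccc(F)c4)c(Cl)c3)c2c1` has not yet been measured. Within the data shown here, it differs from compound 3 by ((ethoxycarbonyl)methyl)(methyl)amino in place of 4-methylpiperazin-1-yl on a saturated chain carbon bound to a triple-bonded carbon, which is the same change, at the same place, as the one from compound 1 to compound 2.

For compound 4 the step of a 2.0-fold higher number from compound 3 to compound 4 (0.29 log units; within the scatter) is expected, resting on the step of an at least 1.8-fold higher number from compound 1 to compound 2 (0.27 log units; that floor lies within the scatter) and on (the limit of > 28 uM in this assay, at which 1 of the 3 values shown sits), since the change on the core of compound 1 moved the number upward to the limit. Compound 4 is accordingly estimated at 16 uM in this assay, with a range from 7 uM to 35 uM, and with a real chance that this assay again reports only a limit.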

Compound 4, half-maximal toxic concentration: > 28 uM
Compound 4: only a limit was reported; the forecaster's own chance of this, stated with the estimate: 30%; middle value at least 1.7-fold (0.24 log units) from the limit.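

In this assay compound 4 gives > 28 uM, which is a limit of the assay and not a number. The step of an at least 3.4-fold higher number from compound 3 to compound 4 (0.53 log units; beyond the scatter) is therefore only a floor, and the change moves the number upward on both cores, although only this floor, and not the earlier one, lies beyond the scatter: the same change on two cores in this assay, an at least 1.8-fold higher number (0.27 log units; that floor lies within the scatter) from compound 1 to compound 2 and an at least 3.4-fold higher number (0.53 log units; beyond the scatter) from compound 3 to compound 4; the limit leaves it open whether they differ The pair of steps thus shows that the direction of the change carried over from the core of compound 1 to the core of compound 3, but it does not show how large the change is on either core, since compound 2 and compound 4 both stop at the same limit: the limit of > 28 uM in this assay, at which 2 of the 4 values shown sit.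

The compounds shown leave open how far compound 2 and compound 4 really lie beyond that limit, and so whether the two cores respond to the change to the same degree. They also leave open whether a carboxylic acid in place of the ethyl ester, or a morpholine or a dimethylamino group on the same saturated chain carbon, would move the number in the same direction, and whether the change carries over to any further core.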